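Replacing 2,3-dihydro-1H-indol-5-yl with 6-aminopyridin-3-yl

The source may hold more compounds than are shown below. What is called first, only, known or untested is meant among the compounds shown, and "the series" means these compounds.

compound 1 `Nc1ccc(-c2ccc3c(c2)oc(=O)n3Cc2ccc(F)cc2)cn1` — 16500 nM
compound 2 `COc1cccc(Cn2c(=O)oc3cc(-c4ccc5c(c4)CCN5)ccc32)c1` — > 100000 nM

Of the compounds shown here, two have been measured in a functional assay on HCT-116 cells (Homo sapiens) for inhibition, read by MTT assay, with a stated time of 72 h; a lower number here means a stronger inhibitor, a higher number a weaker inhibitor. Compound 1 gives 16500 nM. For compound 2 the assay reports only a limit, > 100000 nM, so compound 2 stands at the weak end of what this assay can report (the limit of > 100000 nM in this assay, at which 1 of the 2 values shown sits). Compound 3 `COc1cccc(Cn2c(=O)oc3cc(-c4ccc(N)nc4)ccc32)c1` is next to be measured. It differs from compound 2 in one place: 6-aminopyridin-3-yl in place of 2,3-dihydro-1H-indol-5-yl on an aromatic carbon. Among the compounds with values here, no step between measured compounds is available; the expectation rests on compound 1, which carries the same 6-aminopyridin-3-yl group and gives 16500 nM. The step of an at least 4.0-fold lower number from compound 2 to compound 3 (0.60 log units; beyond the scatter) is expected to move compound 3 out of the limit toward a stronger inhibitor. Compound 3 is estimated at 25000 nM, between 8000 nM and 80000 nM.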

Compound 3, half-maximal inhibitory concentration: 7440 nM
Beside the measured number, compound 3's estimate is 3.4-fold (0.53 log units) above it, and the stated range ends above it.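

In this assay, 6-aminopyridin-3-yl in place of 2,3-dihydro-1H-indol-5-yl on this aromatic carbon turns a compound with no measurable value into one with a number (an at least 13-fold lower number from compound 2 to compound 3 (1.12 log units; beyond the scatter)). As far as these compounds go, compound 2 has only a limit, not a number, so the true size of this step is unknown: the limit of > 100000 nM in this assay, at which 1 of the 3 values shown sits. With 6-aminopyridin-3-yl held constant, 3-methoxyphenyl in place of 4-fluorophenyl on the saturated chain carbon adds a modest further change (a 2.2-fold lower number from compound 1 to compound 3 (0.35 log units; beyond the scatter)). From the compounds shown here alone, whether the amine of the new group is needed remains open. A plain pyridin-3-yl group without that amine would test this.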